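The compounds below may be only part of what the source reports. "The series", "measured", "known", "first", "only" and "open" are said of these compounds alone.

Of the compounds shown here, three of the shared core have been measured in a functional assay on K562 cells (Homo sapiens) for inhibition, read by MTT assay, with a stated time of 48 h; on this read-out lower numbers stand for stronger inhibition and higher numbers for weaker inhibition. Compound 1 `CC(C)(C)C(=O)Nc1ccc(-c2ccc(C(=O)N[C@H]3CN[C@@H](C(=O)Nc4ccc(Cl)c(C(F)(F)F)c4)C3)cc2)cn1` gives 11600 nM; compound 2 `CC(=O)Nc1ccc(-c2cccc(C(=O)N[C@H]3CN[C@@H](C(=O)Nc4ccc(Cl)c(C(F)(F)F)c4)C3)c2)cn1` gives 8710 nM; compound 3 `CCN(CC)C(=O)c1cncc(-c2ccc(C(=O)N[C@@H](C)C(=O)Nc3ccc(Cl)c(C(F)(F)F)c3)cc2)c1` gives 20200 nM. Compound 2 holds the lowest number of the three, yet its gap to compound 1 lies within the scatter, while its gap to compound 3 lies beyond it. Compound 4 `Nc1ccc(-c2cccc(C(=O)N[C@H]3CN[C@@H](C(=O)Nc4ccc(Cl)c(C(F)(F)F)c4)C3)c2)cn1` is not yet measured; it differs from compound 2 by hydrogen in place of acetyl on a nitrogen on an aromatic ring. Among the compounds with values here, no measured pair isolates this change, and compounds 1 and 2 sit within the scatter of each other. In this assay the expected step is therefore small, a 1.1-fold higher number from compound 2 to compound 4 (0.06 log units; within the scatter), with no direction claimed beyond the scatter. Compound 4 is accordingly estimated at 10000 nM, with a range from 4000 nM to 25000 nM.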

Compound 4, half-maximal inhibitory concentration: 20000 nM
Compound 4: the middle estimate sits 2.0-fold (0.30 log units) below what was measured; low and high end bracket the measured number.
By their numbers in this assay, from the lowest: compounds 2, 1, 4 and 3 (each within the scatter of the next, the first and the last beyond it).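

In this assay, within the data shown here, the change from acetamido to amino gives the first single-place comparison, with a 2.3-fold higher number from compound 2 to compound 4 (0.36 log units; beyond the scatter) as a modest step. On this nitrogen on an aromatic ring, the acetyl therefore goes with the stronger inhibition, and its replacement by hydrogen weakens inhibition beyond the scatter. No available measurement gives a reason for this step.

Still open, as far as these compounds go, is whether a methyl group or a longer acyl chain on this nitrogen would keep the number of compound 2 or lower it.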